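This account rests on a few compounds, and the source may have more. Where it says the series, first, only, none or still open, it means among the compounds named here.

Compound 1 `Cc1nc(SCC(=O)Nc2nc(-c3ccc(Cl)cc3)cs2)n(Nc2ccccc2)c1C` carries a chlorophenyl arm and an anilino group on the shared core. In a functional assay on UACC-62 cells (Homo sapiens) for antiproliferative activity, read by sulforhodamine B assay, with a stated time of 48 h (a lower number here means a stronger inhibitor of growth, a higher number a weaker inhibitor of growth), compound 1 gives 16100 nM, the only numeric result in the set, so compound 1 stands at the lone measured point. Among the compounds with values here, compound 2 `Cc1ccc(Nn2c(SCC(=O)Nc3nc(-c4ccccc4)cs3)nc(C)c2C)cc1` differs from compound 1 in two places, so no single step connects them. In this assay compound 2 gives > 100000 nM, which is a limit of the assay and not a number. Of the two values shown, one thus sits at that limit (the limit of > 100000 nM in this assay, at which 1 of the 2 values shown sits). Compound 3 `COc1ccc(Nn2c(SCC(=O)Nc3nc(-c4ccc(Cl)cc4)cs3)nc(C)c2C)cc1` is compound 1 with methoxy in place of hydrogen on an aromatic carbon. Within the data shown here, no step between measured compounds informs this change, and compound 1, at 16100 nM, is already a weak inhibitor of growth in this assay. The step from compound 1 to compound 3 is expected to be small, toward weaker growth inhibition or none beyond the scatter, at a 1.6-fold higher number from compound 1 to compound 3 (0.19 log units; within the scatter). Compound 3 is accordingly estimated at 25000 nM, within 8000 nM to 100000 nM, with a fair chance that the assay returns only a limit.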

Compound 3, concentration for total growth inhibition: > 100000 nM
Compound 3 gave a limit, no number; the forecaster's own chance of this, stated with the estimate: 30%; at least 4.0-fold (0.60 log units) between middle value and limit.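

In this assay, the anilino ring of compound 1 does not accept this change without loss: going from phenyl to 4-methoxyphenyl gives an at least 6.2-fold higher number from compound 1 to compound 3 (0.79 log units; beyond the scatter). The value of compound 3 is a limit of the assay, so this step gives only a minimum size. It is the only single-change step in the series so far, and it shows that one methoxy on an aromatic carbon, para to a large group, is enough to move the chlorophenyl compound to the limit: the limit of > 100000 nM in this assay, at which 2 of the 3 values shown sit.

Going by these compounds, whether this loss is particular to methoxy or also follows from other groups at that carbon, such as fluorine, hydroxyl or an amine, stays open. On these data alone, with compound 1 as the only numeric result, it is also open whether any change on this ring gives stronger growth inhibition.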